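The compounds below may be only part of what the source reports. "The series", "measured", "known", "first", "only" and "open" are said of these compounds alone.

Working notes on the series. In a functional assay on A549 cells (Homo sapiens) for inhibition, read by sulforhodamine B assay, with a stated time of 48 h (on this read-out lower numbers stand for stronger inhibition of growth and higher numbers for weaker inhibition of growth), compound 2 `COC(=O)[C@@]1(C)CCC=C2[C@@H]1CC[C@@H](C)[C@]2(C)Cc1c(C)[nH]c2ccccc12` gives 15000 nM, the higher of the two numbers in hand; compound 1 `COC(=O)[C@@]1(C)CCC=C2[C@@H]1CC[C@@H](C)[C@]2(C)Cc1c[nH]c2c(C)cccc12` gives 11000 nM in the same assay, and the two lie within the scatter of each other. Compound 3 `COC(=O)[C@@]1(C)CCC=C2[C@@H]1CC[C@@H](C)[C@]2(C)Cc1c(C)[nH]c2c(C)cccc12` follows from compound 2 by methyl in place of hydrogen on an aromatic carbon, so it carries the methyl groups of both compound 1 and compound 2. For the measured compounds named here, no measured pair shows this change; with both parents within the scatter, no step beyond the scatter is expected in either direction, and the expected step from compound 2 to compound 3 is a 1.2-fold lower number from compound 2 to compound 3 (0.06 log units; within the scatter). Compound 3 is estimated at 13000 nM in this assay, between 6000 nM and 28000 nM.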

Compound 3, concentration for 50% growth inhibition: 14000 nM
Beside the measured number, compound 3's estimate is 1.1-fold (0.03 log units) below it, and the stated range covers the measured number.
By their numbers in this assay, from the lowest: compounds 1, 3 and 2 (each within the scatter of the next).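

On the six-membered aromatic ring, methyl in place of hydrogen on an aromatic carbon gives a 1.1-fold lower number from compound 2 to compound 3 (0.03 log units; within the scatter) and the methyl at the other place gives a 1.3-fold higher number from compound 1 to compound 3 (0.10 log units; within the scatter) in this assay; both steps lie within the scatter. The two methyl groups can therefore stand on the shared core together without a step beyond the scatter, which the compounds with one of these methyl groups could not show. No evidence on a cause is at hand.

As far as these compounds go, whether an amine, a carboxylic acid or a longer chain on this aromatic carbon would give a step beyond the scatter stays open.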